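Working notes: trifluoromethyl in place of methyl

The source may report more compounds than this note shows. Statements on the series, on what has been measured and on what is new or still open speak of the compounds shown alone.

Measured so far:
Compound 1 `Cc1ccc(S(=O)(=O)N2C[C@@H](CCCO[Si](C)(C)C(C)(C)C)N(C(c3ccccc3)c3ccccc3)C[C@H]2C)cc1` gives 5100 nM in an in vitro assay on HEK293 cells for inhibition of Voltage-dependent L-type calcium channel subunit alpha-1C (Rattus norvegicus), read by FLIPR, with a stated time of 20 min; a higher number here means a weaker inhibitor, a lower number a stronger inhibitor.
Compound 2 `Cc1ccc(S(=O)(=O)N2C[C@@H](CCCCO[Si](C)(C)C(C)(C)C)N(C(c3ccccc3)c3ccccc3)C[C@H]2C)cc1` gives 8200 nM in this assay.

Among the compounds with values here, compound 2 carries the higher of the two numbers, but the single measured step, a 1.6-fold higher number from compound 1 to compound 2 (0.21 log units; within the scatter), lies within the scatter, so compound 1 and compound 2 are not separated in this assay. Compound 3 `C[C@@H]1CN(C(c2ccccc2)c2ccccc2)[C@H](CCCCO[Si](C)(C)C(C)(C)C)CN1S(=O)(=O)c1ccc(C(F)(F)F)cc1` differs from compound 2 in one place: trifluoromethyl in place of methyl on an aromatic carbon. Within the data shown here, no measured step touches this aromatic position; the one step available concerns the chain and offers no guide to the substituent on the aromatic ring. Among the measured compounds shown here, with no precedent, no change beyond the scatter is expected, and the number for compound 3 in this assay is estimated at 8000 nM, with a range of 3000 nM to 20000 nM. The implied step from compound 2, a 1.0-fold lower number from compound 2 to compound 3 (0.01 log units; within the scatter), is expected to stay within the scatter.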

Compound 3, half-maximal inhibitory concentration: 10000 nM
Estimate against measurement, compound 3: 1.3-fold (0.10 log units) below; measured number inside the range.
By their numbers in this assay, from the lowest: compounds 1, 2 and 3 (each within the scatter of the next).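

The aromatic position now has its first measured step: in this assay, going from 4-methylphenyl to 4-(trifluoromethyl)phenyl gives a 1.2-fold higher number from compound 2 to compound 3 (0.09 log units; within the scatter), so trifluoromethyl in place of methyl does not separate the pair. Each of the two positions varied so far, the chain and this aromatic carbon, has one step, and neither step goes beyond the scatter. No measured evidence bears on this result.

Going by these compounds, whether an amine or a carboxylic acid on this aromatic carbon would give a step beyond the scatter remains open. The compounds shown all keep the same shared core and a chain ending in the same silicon-bearing group, so they also leave open what a free hydroxyl at the chain end would do.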